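Replacing 4-chlorophenyl with 3-nitrophenyl on the shared core

The source may report more compounds than this note shows. Statements on the series, on what has been measured and on what is new or still open speak of the compounds shown alone.

In a functional assay on MCF7 cells (Homo sapiens) for inhibition, read by MTT assay, with a stated time of 72 h (on this read-out higher numbers stand for weaker inhibition and lower numbers for stronger inhibition), compound 2 `Cc1cc2occ(-c3nc(-c4ccccc4)c(-c4ccccc4)n3-c3ccc(Cl)cc3)c(=O)c2cc1Cl` gives 12500 nM while compound 1 `COc1ccccc1-n1c(-c2coc3cc(C)c(Cl)cc3c2=O)nc(-c2ccccc2)c1-c1ccccc1` gives 25000 nM and these two numbers lie within the scatter of each other. Compound 3 `Cc1cc2occ(-c3nc(-c4ccccc4)c(-c4ccccc4)n3-c3cccc([N+](=O)[O-])c3)c(=O)c2cc1Cl` keeps the shared core of compound 2 but carries 3-nitrophenyl in place of 4-chlorophenyl on an aromatic nitrogen of the five-membered aromatic ring. Among the compounds with values here, only one measured step bears on this nitrogen, namely a 2.0-fold lower number from compound 1 to compound 2 (0.30 log units; within the scatter) and it exchanges 2-methoxyphenyl for 4-chlorophenyl. That single swap stayed within the scatter, but it is thin evidence, and neither measured compound carries 3-nitrophenyl. The estimated step is a 1.0-fold higher number from compound 2 to compound 3 (0.02 log units; within the scatter) and no shift beyond the scatter is expected in this assay in either direction. For compound 3 the half-maximal inhibitory concentration is estimated at 13000 nM within a range of 5000 nM to 32000 nM around that middle.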

Compound 3, half-maximal inhibitory concentration: 1560 nM
Compound 3: the middle estimate sits 8.3-fold (0.92 log units) above what was measured; the measured number lies below the stated range.
By their numbers in this assay, from the lowest: compound 3; then compounds 2 and 1 (each within the scatter of the next).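

In this assay the group on this aromatic nitrogen proves able to move the number well beyond the scatter, which the earlier swap did not show: 3-nitrophenyl in place of 4-chlorophenyl gives an 8.0-fold lower number from compound 2 to compound 3 (0.90 log units; beyond the scatter) and 3-nitrophenyl in place of 2-methoxyphenyl gives a 16-fold lower number from compound 1 to compound 3 (1.20 log units; beyond the scatter) in the same assay. Compound 3 is therefore the most potent of these three, with both of its steps beyond the scatter. Nothing at hand explains why this change has such an effect.

Still open, as far as these compounds go, is whether the nitro group itself or its placement on the phenyl ring accounts for the shift, a question that 4-nitrophenyl and 3-chlorophenyl on the same nitrogen could help to separate. From the compounds shown here alone, it is also open how 3-aminophenyl or 3-carboxyphenyl would compare there.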